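The source may hold more compounds than are shown below. What is called first, only, known or untested is meant among the compounds shown, and "the series" means these compounds.

Of the compounds shown here, three have been measured in a functional assay on HCT-116 cells (Homo sapiens) for inhibition, read by sulforhodamine B assay, with a stated time of 48 h, tested at 50 uM; a lower number here means less inhibition of growth, a higher number more inhibition of growth at the concentration tested. Compound 1 `COc1ccc(/C=C/C(=O)/C=C/c2ccc(OCc3cn(CCCCCOc4cc(=O)oc5ccccc45)nn3)c(OC)c2)cc1OC` gives 45%, compound 2 `COc1ccc(/C=C/C(=O)/C=C/c2ccc(OCc3cn(CCCCCOc4cc(=O)oc5ccccc45)nn3)c(OC)c2)cc1` gives 35%, and compound 3 `COc1ccc(/C=C/C(=O)/C=C/c2ccc(OCc3cn(CCCOc4cc(=O)oc5ccccc45)nn3)c(OC)c2)cc1` gives 54%. Compound 3 shows the highest of the three numbers, though its gap to compound 1 lies within the scatter; only its gap to compound 2 lies beyond it. The difference between the core of compound 1 and the core of compound 3 is not broken down here. Compound 2 differs from compound 1 by hydrogen in place of methoxy on an aromatic carbon, and this brought a number 10 percentage points lower from compound 1 to compound 2 (within the scatter). Compound 4 `COc1cc(/C=C/C(=O)/C=C/c2ccccc2)ccc1OCc1cn(CCCOc2cc(=O)oc3ccccc23)nn1` is not yet measured; it differs from compound 3 by hydrogen in place of methoxy on an aromatic carbon. This is the same kind of change, but at a different place: in compound 1 the leaving methoxy sits ortho to a methoxy group and meta to a large group, whereas in compound 3 it sits para to a large group. Resting on a number 10 percentage points lower from compound 1 to compound 2 (within the scatter), a step of similar size is expected, namely a number 10 percentage points lower from compound 3 to compound 4 (within the scatter). Compound 4 is therefore estimated to give 44%, within a range from 25% to 62%.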

Compound 4, percent growth inhibition at one concentration: 45%
The estimate for compound 4 lay 1 percentage points below the measured number; low and high end bracket the measured number.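

In this assay, putting hydrogen in place of methoxy brought a number 9 percentage points lower from compound 3 to compound 4 (within the scatter), and the earlier case of the same change gives a closely similar step on a different core: the same change on two cores in this assay, a number 10 percentage points lower (within the scatter) from compound 1 to compound 2 and a number 9 percentage points lower (within the scatter) from compound 3 to compound 4, 1 percentage points apart, within the scatter of two such steps Within these two pairs, then, the change carried over from one core to the other at a similar size, even though it sat at a different place in each. Each step lies within the scatter, however, so neither pair shows that removing the methoxy group truly alters growth inhibition, and two pairs cannot establish a rule for other cores in the series.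

The compounds shown carry only methoxy or hydrogen at the position that changes, so it remains open whether a hydroxyl group, an amine or a chlorine atom there would give a step beyond the scatter. Going by these compounds, it also remains open whether the methoxy-to-hydrogen change would give a similar step on a core bearing a carboxylic acid.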